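This account rests on a few compounds, and the source may have more. Where it says the series, first, only, none or still open, it means among the compounds named here.

Measured in a physicochemical assay for solubility; on this read-out higher numbers stand for higher solubility and lower numbers for lower solubility:
- compound 1 `O=C(CN1CCNCC1)N1CCC(NS(=O)(=O)c2cc(S(=O)(=O)c3ccccc3)ccc2C(F)(F)F)CC1`: 50000 nM
- compound 2 `O=C([C@@H]1CCCN1C(=O)Nc1ccccc1)N1CCC(NS(=O)(=O)c2cc(S(=O)(=O)c3ccccc3)ccc2C(F)(F)F)CC1`: 25000 nM
- compound 3 `O=C([C@@H]1CCCN1C(=O)N1CCOCC1)N1CCC(NS(=O)(=O)c2cc(S(=O)(=O)c3ccccc3)ccc2C(F)(F)F)CC1`: 50000 nM

Compound 3, at 50000 nM, reads level with compound 1 at the digits shown, and the three values lie within the scatter of one another. Compound 4 `CN1CCC[C@H]1C(=O)N1CCC(NS(=O)(=O)c2cc(S(=O)(=O)c3ccccc3)ccc2C(F)(F)F)CC1` carries methyl in place of (morpholin-4-yl)carbonyl on an amine nitrogen in a ring.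

Among the compounds with values here, only one measured step bears directly on this change. That step, a 2.0-fold higher number from compound 2 to compound 3 (0.30 log units; within the scatter), swaps the group on a carbonyl carbon but keeps the carbonyl, so it does not test the loss of the whole group. Compound 1, which has no (morpholin-4-yl)carbonyl, still gives 50000 nM. With so few data, no shift beyond the scatter is expected in this assay, and no direction can be argued with confidence. The expected step is a 1.3-fold lower number from compound 3 to compound 4 (0.10 log units; within the scatter). For compound 4 the estimated value is 40000 nM, with an expected range of 15000 nM to 100000 nM.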

Compound 4, solubility: 100000 nM
Compound 4: middle estimate off by 2.5-fold (0.40 log units), on the low side; the measured number falls inside the stated range.
By their numbers in this assay, from the lowest: compounds 2, 1, 3 and 4 (each within the scatter of the next, the first and the last beyond it).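

In this assay, the whole (morpholin-4-yl)carbonyl can give way to methyl on the amine nitrogen in the ring with only a 2.0-fold higher number from compound 3 to compound 4 (0.30 log units; within the scatter) as the result, so loss of the group, and not merely a swap on its carbonyl carbon, is now tested. Methyl in place of phenylcarbamoyl gives a 4.0-fold higher number from compound 2 to compound 4 (0.60 log units; beyond the scatter) and is the only step in the series beyond the scatter, whereas 1-methylpyrrolidin-2-yl in place of (piperazin-1-yl)methyl on a carbonyl carbon gives a 2.0-fold higher number from compound 1 to compound 4 (0.30 log units; within the scatter) and does not separate those two compounds. No measurement available explains these steps.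

From the compounds shown here alone, how far this position depends on methyl itself remains open. An ethyl group, a bare amine hydrogen or a chain ending in a carboxylic acid on the same nitrogen would show whether the reading holds beyond these compounds.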